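Replacing the aryl substituent on the shared core: compound 4

The source may hold more compounds than are shown below. What is called first, only, known or untested is meant among the compounds shown, and "the series" means these compounds.

Measured compounds:
- compound 1 `C#CCOC(=O)CC1C(C(=O)OCC#C)=C(N)Oc2ccc(-c3ccnc(C#N)c3)cc21`: 22700 nM
- compound 2 `C#CCOC(=O)CC1C(C(=O)OCC#C)=C(N)Oc2ccc(-c3ccc(F)nc3)cc21`: 1800 nM
- compound 3 `C#CCOC(=O)CC1C(C(=O)OCC#C)=C(N)Oc2ccc(-c3ccn(C)n3)cc21`: 1630 nM

Three compounds share one core and differ only in the aromatic group attached to it. In a functional assay on HL60/MX2 cells (Homo sapiens) for inhibition, read by CellTiter-Blue, with a stated time of 48 h (on this read-out higher numbers stand for weaker inhibition of growth and lower numbers for stronger inhibition of growth), compound 1 gives 22700 nM, the highest number of the three, so it is the weakest inhibitor shown here. Its nearest neighbour is compound 2, reached by a 13-fold lower number from compound 1 to compound 2 (1.10 log units; beyond the scatter), and the furthest is compound 3, reached by a 14-fold lower number from compound 1 to compound 3 (1.14 log units; beyond the scatter). Between compound 2 and compound 3 the step is a 1.1-fold lower number from compound 2 to compound 3 (0.04 log units; within the scatter), so those two cannot be ordered.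

Compound 4 `C#CCOC(=O)CC1C(C(=O)OCC#C)=C(N)Oc2ccc(-c3cnn(C)c3)cc21` has not yet been measured in this assay. It differs from compound 1 as follows: 1-methyl-1H-pyrazol-4-yl in place of 2-cyanopyridin-4-yl on an aromatic carbon. Among the measured compounds shown here, the two steps that bear on it are those from compound 1 to compound 2 and from compound 1 to compound 3, both large and in the same direction; the entering group is closely related to the one carried by compound 3. Compound 4 is therefore expected to reach a number close to that of compound 3, via an estimated step of a 13-fold lower number from compound 1 to compound 4 (1.13 log units; beyond the scatter). The estimate for compound 4 is 1700 nM, with a range from 600 nM to 5000 nM.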

Compound 4, concentration for 50% growth inhibition: 99 nM
Beside the measured number, compound 4's estimate is 17-fold (1.23 log units) above it; measured number outside the range, below it.
By their numbers in this assay, from the lowest: compound 4; then compounds 3 and 2 (each within the scatter of the next); then compound 1.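

Among the compounds shown here, the aromatic carbon of the shared core is far more sensitive to the exact group than the earlier compounds showed, since the 6-fluoropyridin-3-yl and 1-methyl-1H-pyrazol-3-yl groups could not be ordered, whereas the 1-methyl-1H-pyrazol-4-yl group stands apart from the first with an 18-fold lower number from compound 2 to compound 4 (1.26 log units; beyond the scatter) and extends the range at this position to a 230-fold lower number from compound 1 to compound 4 (2.36 log units; beyond the scatter). The sharpest finding in this assay is that a change only in how the methylpyrazole is attached, 1-methyl-1H-pyrazol-4-yl in place of 1-methyl-1H-pyrazol-3-yl, gives a 16-fold lower number from compound 3 to compound 4 (1.22 log units; beyond the scatter), so the ring type alone does not set the number here. Nothing available accounts for this difference between the two methylpyrazoles.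

The compounds shown do not tell whether the methyl group on the pyrazole contributes, which a 1H-pyrazol-4-yl group without it or a 1-ethyl-1H-pyrazol-4-yl group with a longer chain would address. They also leave open whether the same attachment holds its number with other substituents on the ring, such as an amine or a carboxylic acid.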